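From 2-chlorophenyl to 3-bromophenyl at the assay limit

The compounds below may be only part of what the source reports. "The series", "measured", "known", "first", "only" and "open" are said of these compounds alone.

In an ADME assay on MDBK cells (Bos taurus) for cytotoxicity (on this read-out lower numbers stand for higher toxicity in this test and higher numbers for lower toxicity in this test), compound 3 (`Clc1ccccc1Cn1ccc2nc(-c3ccccc3)nc-2c1`) gives > 100000 nM, which is a limit and not a number. Compound 1 (`Cc1ccccc1Cn1ccc2nc(-c3ccccc3)nc-2c1`) gives > 100000 nM, also a limit. Compound 2 (`COc1cccc(Cn2ccc3nc(-c4ccccc4)nc-3c2)c1`) gives > 100000 nM, again a limit. Compound 3 therefore has no exact position among them: the evidence is the limit of > 100000 nM in this assay, at which 3 of the 3 values shown sit.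

Compound 4 (`Brc1cccc(Cn2ccc3nc(-c4ccccc4)nc-3c2)c1`) has 3-bromophenyl in place of 2-chlorophenyl on a saturated chain carbon bound to an aromatic nitrogen. The nearest measured changes are a step that the two limits leave unreadable from compound 1 to compound 2, a step that the two limits leave unreadable from compound 2 to compound 3 and a step that the two limits leave unreadable from compound 1 to compound 3. None has a readable size.

The expectation in this assay is no change beyond the scatter, with an estimated step of a number no higher from compound 3 to compound 4 (the limit leaves the size open). For compound 4, the estimate is 100000 nM, with an expected range from 50000 nM to 200000 nM.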

Compound 4, half-maximal cytotoxic concentration: 85000 nM
The estimate for compound 4 lay 1.2-fold (0.07 log units) above the measured number; the measured number falls inside the stated range.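

Compound 4 is the only compound shown with an exact number in this assay, and this gives the first readable steps at this position: an at least 1.1-fold lower number from compound 3 to compound 4 (0.07 log units; that floor lies within the scatter), an at least 1.1-fold lower number from compound 2 to compound 4 (0.07 log units; that floor lies within the scatter) and an at least 1.1-fold lower number from compound 1 to compound 4 (0.07 log units; that floor lies within the scatter). These are floors within the scatter, so 3-bromophenyl on a saturated chain carbon bound to an aromatic nitrogen shows no clear shift from the other groups. The steps among the remaining compounds cannot be read, as their values are limits: the limit of > 100000 nM in this assay, at which 3 of the 4 values shown sit.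

The compounds shown leave open whether an amine or a carboxylic acid in place of the bromo would move the number beyond the scatter.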